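This account rests on a few compounds, and the source may have more. Where it says the series, first, only, none or still open, it means among the compounds named here.

Measured compounds:
- Compound 1, `Nc1cc(N)c2nc(-c3ccccc3)c(Oc3ccc(Cl)c(Cl)c3)nc2c1`; in a functional assay on SK-MEL-28 cells (Homo sapiens) for inhibition, read by sulforhodamine B assay, with a stated time of 48 h (on this read-out higher numbers stand for lower toxicity in this test and lower numbers for higher toxicity in this test), compound 1 gives < 100000 nM, which is a limit of the assay and not a number.
- Compound 2, `CCOC(=O)[C@H](CCC(=O)O)NC(=O)c1ccc(Oc2nc3cc(N)cc(N)c3nc2-c2ccccc2)cc1`; in this assay compound 2 gives 64600 nM.

On the numbers shown, compound 1 stands only at a limit: the limit of < 100000 nM in this assay, at which 1 of the 2 values shown sits, so no exact figure is known for it. Compound 3, `Nc1cc(N)c2nc(-c3ccccc3)c(NCc3ccc(F)cc3)nc2c1`, is not yet measured. It differs from compound 1 in one place: (4-fluorobenzyl)amino in place of 3,4-dichlorophenoxy on an aromatic carbon, that is, a (4-fluorobenzyl)amino in place of 3,4-dichlorophenoxy on an aromatic carbon of the shared core. For the measured compounds named here, no measured pair with a single change of this kind is available, so the size of the step cannot be read from data; the expectation is a step of no size beyond the scatter, in no particular direction, a step that the limit leaves unreadable from compound 1 to compound 3. On that basis compound 3 is estimated at 50000 nM in this assay, within a range from 15000 nM to 150000 nM.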

Compound 3, concentration lethal to 50% of the cells: 7410 nM
Compound 3: middle estimate off by 6.7-fold (0.83 log units), on the high side, and the stated range ends above it.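

No step can be read from compound 1 to compound 3, since the value of compound 1 is a limit of the assay and not a number: the limit of < 100000 nM in this assay, at which 1 of the 3 values shown sits. The compounds shown leave open how far (4-fluorobenzyl)amino in place of 3,4-dichlorophenoxy on the shared core changes the lethal concentration.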